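Swapping 4-ethoxyphenyl for a methoxy-bearing pyridine

This account rests on a few compounds, and the source may have more. Where it says the series, first, only, none or still open, it means among the compounds named here.

In a functional assay on HeLa cells (Homo sapiens) for antiproliferative activity, read by CCK-8 assay, with a stated time of 72 h (on this read-out lower numbers stand for stronger inhibition and higher numbers for weaker inhibition), compound 1 `COc1ccc(-c2cncnc2-c2cc(OC)c(OC)c(OC)c2)cc1` gives 1140 nM, and compound 2 `CCOc1ccc(-c2cncnc2-c2cc(OC)c(OC)c(OC)c2)cc1` gives 250 nM, the lower of the two numbers. Among the measured compounds shown here, the one measured step, a 4.6-fold lower number from compound 1 to compound 2 (0.66 log units; beyond the scatter), goes with methyl in place of hydrogen on a chain carbon bound to oxygen. Compound 3 `COc1ccc(-c2cncnc2-c2cc(OC)c(OC)c(OC)c2)nc1` has 5-methoxypyridin-2-yl in place of 4-ethoxyphenyl on an aromatic carbon. For the measured compounds named here, it returns to the methoxy of compound 1, which stands at 1140 nM, while no measured step covers the added ring nitrogen. A weaker result in this assay is therefore expected, with an estimated 4.8-fold higher number from compound 2 to compound 3 (0.68 log units; beyond the scatter). For compound 3 the estimate is 1200 nM, ranging from 350 nM to 4000 nM.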

Compound 3, half-maximal inhibitory concentration: 470 nM
Estimate against measurement, compound 3: 2.6-fold (0.41 log units) above; the measured number falls inside the stated range.
By their numbers in this assay, from the lowest: compounds 2 and 3 (each within the scatter of the next); then compound 1.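

In this assay, 5-methoxypyridin-2-yl in place of 4-ethoxyphenyl gives a 1.9-fold higher number from compound 2 to compound 3 (0.27 log units; within the scatter), so at this position the two groups cannot be told apart. With the methoxy kept, 5-methoxypyridin-2-yl in place of 4-methoxyphenyl gives a 2.4-fold lower number from compound 1 to compound 3 (0.38 log units; beyond the scatter), showing that a change in the ring itself, not only a longer chain on its oxygen, can go with a lower number. No measurement here explains either step. Still open, on these data alone, is whether 5-ethoxypyridin-2-yl would combine the ethoxy chain with the ring nitrogen to give a lower number, and how a propoxy chain or an amine would fare.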